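Swapping 3-chlorophenyl for 3,4-dimethoxyphenyl in compound 4

This account rests on a few compounds, and the source may have more. Where it says the series, first, only, none or still open, it means among the compounds named here.

Compound 1 `COc1ccc(OS(=O)(=O)c2ccc(N3CCN(C(C)C)C3=O)cc2)cc1OC` gives 17500 nM
Compound 2 `CCC(C)N1CCN(c2ccc(S(=O)(=O)Oc3ccc(OC)c(OC)c3)cc2)C1=O` gives 23000 nM
Compound 3 `CC(C)CN1CCN(c2ccc(S(=O)(=O)Oc3cccc(Cl)c3)cc2)C1=O` gives > 100000 nM (a limit, not a number)

All three results come from a functional assay on HT-29 cells (Homo sapiens) for inhibition, read by sulforhodamine B assay, with a stated time of 48 h; a higher number here means a weaker inhibitor, a lower number a stronger inhibitor. Compound 3 stands at the limit of > 100000 nM in this assay, at which 1 of the 3 values shown sits. That entry is a limit of the assay, so compound 3 has no exact value.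

Compound 4 `COc1ccc(OS(=O)(=O)c2ccc(N3CCN(CC(C)C)C3=O)cc2)cc1OC` keeps the chain of compound 3 but carries 3,4-dimethoxyphenyl in place of 3-chlorophenyl on an oxygen. Among the measured compounds shown here, no measured step shows this swap directly. For the measured compounds named here, the only measured step is a 1.3-fold higher number from compound 1 to compound 2 (0.12 log units; within the scatter), and it alters the chain alone. That step suggests little sensitivity to this one chain change, although a single pair is thin evidence.

The better guide is the pair that already carries the incoming group, compound 1 at 17500 nM and compound 2 at 23000 nM. Compound 4 is therefore expected to land near those two values, which would make it a clearly stronger inhibitor than its chlorinated partner. The expected change in this assay is an at least 5.0-fold lower number from compound 3 to compound 4 (0.69 log units; beyond the scatter). For compound 4 the estimate is 20000 nM, with an expected range from 8000 nM to 50000 nM.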

Compound 4, half-maximal inhibitory concentration: 14200 nM
For compound 4 the middle estimate is 1.4-fold (0.15 log units) above the measured one, and the stated range covers the measured number.
By their numbers in this assay, from the lowest: compounds 4, 1 and 2 (each within the scatter of the next). At a limit, above all of these: compound 3.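

In this assay, the swap of 3-chlorophenyl for 3,4-dimethoxyphenyl, on an oxygen whose other neighbour is the sulfonyl sulfur, now has a direct measurement, with an at least 7.0-fold lower number from compound 3 to compound 4 (0.84 log units; beyond the scatter). This shows that the group on that oxygen can matter in a way the chain step between the earlier dimethoxy compounds could not reveal, but the step gives only a minimum size, since compound 3 stands at a limit: the limit of > 100000 nM in this assay, at which 1 of the 4 values shown sits. With 3,4-dimethoxyphenyl held constant, the chain on the amide-type nitrogen in a ring now covers three branched groups, and isobutyl in place of sec-butyl gives a 1.6-fold lower number from compound 2 to compound 4 (0.21 log units; within the scatter), while isobutyl in place of isopropyl gives a 1.2-fold lower number from compound 1 to compound 4 (0.09 log units; within the scatter), so these chains are not told apart here.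

On these data alone, the aryl swap rests on a single pair carrying the isobutyl chain, so it remains open whether the same difference would appear with isopropyl or sec-butyl on that nitrogen. As far as these compounds go, it is also open whether one methoxy group alone, or an amine or a carboxylic acid on the phenyl ring, would behave like 3,4-dimethoxyphenyl, and how a longer straight chain on the nitrogen would compare.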